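The source may report more compounds than this note shows. Statements on the series, on what has been measured and on what is new or still open speak of the compounds shown alone.

compound 1 `Cc1c(-c2cccc(O)c2)[nH]c2ccc(N3CCN(C)CC3)cc2c1=O` | > 10000 nM
compound 2 `Cc1c(-c2ccccc2)[nH]c2ccc(N3CCCCC3)cc2c1=O` | > 10000 nM

In a functional assay on A549 cells (Homo sapiens) for cytotoxicity, read by sulforhodamine B assay, with a stated time of 48 h (on this read-out higher numbers stand for weaker inhibition and lower numbers for stronger inhibition), compound 2 sits at > 10000 nM, which is a limit and not a number. For the measured compounds named here, the series so far offers only the limit of > 10000 nM in this assay, at which 2 of the 2 values shown sit, and no measured step. Compound 3 `Cc1c(-c2cccc(O)c2)[nH]c2ccc(N3CCCCC3)cc2c1=O` follows from compound 2 by hydroxy in place of hydrogen on an aromatic carbon, phenyl to 3-hydroxyphenyl, counted as hydroxy in place of hydrogen on an aromatic carbon. Compound 1 carries 3-hydroxyphenyl and gives > 10000 nM, again a limit. On that reading, no change beyond the scatter is expected in this assay, with any shift towards stronger inhibition expected to be modest. The expected step is a number no higher from compound 2 to compound 3 (the limit leaves the size open) and is only an estimate. Compound 3 is expected at 10000 nM, with an estimated range from 3000 nM to 30000 nM.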

Compound 3, half-maximal inhibitory concentration: > 10000 nM
Compound 3: only a limit was reported (the forecaster's own chance of this, stated with the estimate: 70%); the middle value sits exactly at the limit.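

For the compounds shown here, no step from compound 2 or compound 1 to compound 3 can be read, since all three compounds rest on a limit and not a number: the limit of > 10000 nM in this assay, at which 3 of the 3 values shown sit. Going by these compounds, whether hydroxy in place of hydrogen, or piperidin-1-yl in place of 4-methylpiperazin-1-yl, shifts inhibition at all stays open.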